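A few compounds are considered here, and "the series" means these few. Any claim that something is new, unique, unknown or untested is made for them only; others in the source may bear on it.

In an ADME assay on MT4 cells (Homo sapiens) for activation, read by MTT assay (on this read-out higher numbers stand for lower toxicity in this test and lower numbers for higher toxicity in this test), compound 2 `CCC(c1nc(SC(C)C)[nH]c(=O)c1C)c1c(F)cccc1Cl` gives only a limit, > 3000 nM. Compound 1 `CCCSc1nc(Cc2c(F)cccc2Cl)c(C)c(=O)[nH]1` also gives only a limit, > 76000 nM. Among the measured compounds shown here, compound 3 `CCCSc1nc(C(CC)c2c(F)cccc2Cl)c(C)c(=O)[nH]1` has propyl in place of isopropyl on a sulfur, the one change from compound 2: propyl in place of isopropyl on a sulfur. For the measured compounds named here, no measured pair shows this change, so the size of the move in this assay remains uncertain. The estimated step that the limit leaves unreadable from compound 2 to compound 3 is expected to point upward, towards lower toxicity in this test. For compound 3 the expected value is 20000 nM, with an estimated range of 4000 nM to 100000 nM.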

Compound 3, half-maximal cytotoxic concentration: > 3000 nM
Compound 3 gave a limit, no number; the forecaster's own chance of this, stated with the estimate: 65%; the middle value lies beyond the limit too.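

In this assay, among the compounds shown here, compound 1, compound 2 and compound 3 all give only limits, and no step from compound 1 or compound 2 to compound 3 can be read. On these data alone, whether propyl in place of isopropyl on a sulfur, or ethyl in place of hydrogen on the saturated chain carbon, changes toxicity in this test stays open.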